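Dropping the methoxy group from compound 2

The source may report more compounds than this note shows. Statements on the series, on what has been measured and on what is new or still open speak of the compounds shown alone.

Measured so far:
compound 1 `CCC1=C(O)c2c(oc(-c3ccc(C)cc3C)cc2=O)C(CC)(CC)C1=O` gives 8.52 uM
compound 2 `CCC1=C(O)c2c(oc(-c3ccc(OC)c(C)c3C)cc2=O)C(CC)(CC)C1=O` gives 0.28 uM

In a functional assay on KBVIN cells (Homo sapiens) for antiproliferative activity, read by sulforhodamine B assay, with a stated time of 3 days (a lower number here means that less compound is needed, a higher number that more compound is needed for the effect), compound 2 at 0.28 uM holds the lower of the two numbers, and the gap up to compound 1 lies beyond the scatter. Compound 3 `CCC1=C(O)c2c(oc(-c3cccc(C)c3C)cc2=O)C(CC)(CC)C1=O` follows from compound 2 by one change (hydrogen in place of methoxy on an aromatic carbon), hydrogen in place of methoxy on an aromatic carbon. Going by the values given here, no measured pair isolates this change. Among the compounds with values here, compound 1 also lacks the methoxy and gives 8.52 uM in this assay as the only guide, though it differs from compound 3 in where a methyl group stands. The estimated step is an 8.9-fold higher number from compound 2 to compound 3 (0.95 log units; beyond the scatter) and is expected to lie beyond the scatter, toward a higher number. For compound 3 the estimated value is 2.5 uM (0.6 uM to 10 uM).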

Compound 3, concentration for half-maximal effect: 0.85 uM
The estimate for compound 3 lay 2.9-fold (0.47 log units) above the measured number, within the range that was stated.
By their numbers in this assay, from the lowest: compound 2; then compound 3; then compound 1.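

In this assay, the step of a 3.0-fold higher number from compound 2 to compound 3 (0.48 log units; beyond the scatter) isolates the methoxy group: its replacement by hydrogen at the place para to a large group moves the number beyond the scatter, yet compound 3 still stands well clear of compound 1. The 2,3-dimethylphenyl in place of 2,4-dimethylphenyl change gives a 10-fold lower number from compound 1 to compound 3 (1.00 log units; beyond the scatter), a larger step than the methoxy change, so the arrangement of the methyl groups matters more here than the methoxy group. No data at hand bear on the origin of either step.

On these data alone, whether the methoxy step would hold on the 2,4-dimethylphenyl compound stays open, since methoxy appears here only in compound 2. Also open, as far as these compounds go, is how an ethoxy group, a hydroxyl group, an amine or a halogen such as fluorine would read at this place.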